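The source may hold more compounds than are shown below. What is called first, only, known or untested is meant among the compounds shown, and "the series" means these compounds.

Compound 1 `CC1(C)CC12NC(=O)N(NC(=O)c1ccc(Br)cc1)C2=O` and compound 2 `CC1(C)CC12NC(=O)N(NC(=O)c1ccc(F)cc1)C2=O` share one core and differ only in the halogen on an aromatic carbon. In a functional assay on the whole organism (Hindlimb) for inhibition, with Mus musculus as the target, with a stated time of 4 h (on this read-out higher numbers stand for an effect only at larger amounts of compound and lower numbers for an effect already at smaller amounts), compound 1 gives 300 mg/kg. In this assay compound 2 gives 300 mg/kg. For the measured compounds named here, the step of no change at the digits printed from compound 1 to compound 2 (within the scatter) shows that exchanging one halogen for another left the read-out where it was, so compound 2 stands level with compound 1 on the numbers so far. Compound 3 `CC1(C)CC12NC(=O)N(NC(=O)c1ccncc1)C2=O` carries pyridin-4-yl in place of 4-fluorophenyl on a carbonyl carbon. Going by the values given here, no measured step exchanges a carbon-only aromatic ring for one holding a nitrogen, so the only guide is that the single measured change, no change at the digits printed from compound 1 to compound 2 (within the scatter), stayed within the scatter. On that basis the expected step is no change at the digits printed from compound 2 to compound 3 (within the scatter), with no direction favoured and nothing beyond the scatter anticipated. Compound 3 is therefore estimated to give 300 mg/kg in this assay, with a range from 100 mg/kg to 600 mg/kg.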

Compound 3, minimum effective dose: 300 mg/kg
Estimate against measurement, compound 3: no gap at the digits printed, within the range that was stated.
By their numbers in this assay, from the lowest: compounds 1, 2 and 3 (each within the scatter of the next).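

Exchanging 4-fluorophenyl for pyridin-4-yl on the carbonyl carbon gives no change at the digits printed from compound 2 to compound 3 (within the scatter) in this assay and, set against 4-bromophenyl, no change at the digits printed from compound 1 to compound 3 (within the scatter) as well. The earlier pair differed only in a halogen on a carbon-only ring, whereas here the ring itself changes to one holding a nitrogen and a hydrogen-bond acceptor, and the read-out still stays level. Nothing available explains why this larger change leaves the read-out in place.

From the compounds shown here alone, all three compounds carry a six-membered aromatic ring at this place, so it remains open how a saturated ring such as cyclohexyl, a short alkyl chain, or a phenyl ring bearing an amine would read. With all three level, the compounds shown also give no sign of which change at this place would move the minimum effective dose in either direction.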